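This account rests on a few compounds, and the source may have more. Where it says the series, first, only, none or still open, it means among the compounds named here.

In a functional assay on U-87MG ATCC cells for inhibition, with U-87 MG (Homo sapiens) as the target, read by MTT assay, with a stated time of 72 h (a lower number here means a stronger inhibitor, a higher number a weaker inhibitor), compound 1 `Oc1c(C(Nc2ccccn2)c2ccccc2F)ccc2cccnc12` gives > 10000 nM, which is a limit of the assay and not a number. Compound 2 `COc1cccc(C(Nc2ccccn2)c2ccc3cccnc3c2O)c1` gives 11900 nM, and compound 3 `Oc1c(C(Nc2ccccn2)c2ccc(Cl)cc2)ccc2cccnc12` gives 10600 nM. Compound 3 therefore stands level with compound 2 within the scatter, and it cannot be placed exactly against compound 1.

The next analogue, compound 4 `CCc1ccc(C(Nc2ccccn2)c2ccc3cccnc3c2O)cc1`, carries ethyl in place of chloro on an aromatic carbon, turning 4-chlorophenyl into 4-ethylphenyl: ethyl in place of chloro on an aromatic carbon. Three measured steps change the same aromatic group. Two give no size: a step that the limit leaves unreadable from compound 1 to compound 2 and a step that the limit leaves unreadable from compound 1 to compound 3. The only readable one is a 1.1-fold lower number from compound 2 to compound 3 (0.05 log units; within the scatter). With that single step as the guide, no change beyond the scatter is expected in this assay, and no direction can be favoured. The expected move is a 1.0-fold higher number from compound 3 to compound 4 (0.02 log units; within the scatter). Compound 4 is estimated at 11000 nM, with an expected range from 5500 nM to 22000 nM.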

Compound 4, half-maximal inhibitory concentration: 9300 nM
Estimate against measurement, compound 4: 1.2-fold (0.07 log units) above; the range from low to high includes it.
By their numbers in this assay, from the lowest: compounds 4, 3 and 2 (each within the scatter of the next).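

In this assay, ethyl in place of chloro on this aromatic carbon, para to a large group, gives a 1.1-fold lower number from compound 3 to compound 4 (0.06 log units; within the scatter), so at this position a two-carbon chain and a halogen cannot be told apart. The comparison with the 3-methoxyphenyl analogue reads the same way, with a 1.3-fold lower number from compound 2 to compound 4 (0.11 log units; within the scatter), so 4-ethylphenyl also leaves the number within the scatter of that differently placed group. The value of compound 1 is a limit of the assay, so its step gives only a floor, an at least 1.0-fold lower number from compound 1 to compound 4 (0.03 log units; that floor lies within the scatter), and the readable values of this small set stay close to that limit: the limit of > 10000 nM in this assay, at which 1 of the 4 values shown sits.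

As far as these compounds go, whether an amine, a carboxylic acid or a longer chain on this carbon would move the number beyond the scatter stays open. So does whether any change to the shared core would do so.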